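The source may hold more compounds than are shown below. What is called first, only, known or untested is meant among the compounds shown, and "the series" means these compounds.

Going by the values given here, in a functional assay on OVCAR-8 cells (Homo sapiens) for antiproliferative activity, read by sulforhodamine B assay, with a stated time of 48 h (a lower number here means a stronger inhibitor, a higher number a weaker inhibitor), compound 1 `O=C(NCCCNc1cc(-c2cn(-c3ccccc3)nc2-c2cccc(O)c2)ccn1)Nc1ccc(F)cc1` gives 2130 nM and compound 2 `O=C(NCCCNc1cc(-c2cn(-c3ccccc3)nc2-c2cccc(O)c2)ccn1)Nc1cccc(C(F)(F)F)c1` gives 3880 nM so compound 1 stands within the scatter of the only other measured compound. Compound 3 `COc1cccc(-c2nn(-c3ccccc3)cc2-c2ccnc(NCCCNC(=O)Nc3ccc(F)cc3)c2)c1` differs from compound 1 by methyl in place of hydrogen on an oxygen on an aromatic ring which turns 3-hydroxyphenyl into 3-methoxyphenyl. Among the compounds with values here, the one measured step of a 1.8-fold higher number from compound 1 to compound 2 (0.26 log units; within the scatter) changes a different group and leaves this oxygen untested, so no step beyond the scatter is expected, and the estimate of a 1.4-fold higher number from compound 1 to compound 3 (0.15 log units; within the scatter) has an uncertain direction. Compound 3 is expected to give 3000 nM with an estimated range from 1000 nM to 9000 nM in this assay when measured.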

Compound 3, half-maximal inhibitory concentration: 10600 nM
For compound 3 the middle estimate is 3.5-fold (0.55 log units) below the measured one; measured number above the stated range.
By their numbers in this assay, from the lowest: compounds 1 and 2 (each within the scatter of the next); then compound 3.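

In this assay, methyl in place of hydrogen on the oxygen gives a 5.0-fold higher number from compound 1 to compound 3 (0.70 log units; beyond the scatter), so the compound is weakened when 3-hydroxyphenyl becomes 3-methoxyphenyl. Unlike the earlier swap on the amide-type nitrogen, which stayed within the scatter, this change lies beyond it, so the free hydroxy cannot be exchanged for methoxy here without loss. Nothing measured here gives a reason for this loss. From the compounds shown here alone, whether an amine or a carboxylic acid in place of the hydroxy would keep the activity remains open. So does whether methoxy would cost as much alongside the 3-(trifluoromethyl)phenyl group of compound 2.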